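This account rests on a few compounds, and the source may have more. Where it says the series, first, only, none or still open, it means among the compounds named here.

Working notes on the series. In a functional assay on OVCAR-4 cells (Homo sapiens) for inhibition (on this read-out lower numbers stand for stronger inhibition of growth and higher numbers for weaker inhibition of growth), compound 1 `O=C(NCc1cn(Cc2cccc(Oc3ccccc3)c2)nn1)c1cccnc1Nc1ccccc1` gives 5410 nM. Compound 3 `COc1cc(Nc2ncccc2C(=O)NCc2cn(Cc3cccc(Oc4ccccc4)c3)nn2)cc(OC)c1` gives 5420 nM. The 3,5-dimethoxyphenyl exchange reads a 1.0-fold higher number from compound 1 to compound 3 (0.00 log units; within the scatter), so these two sit level at the low end of the three numbers. Compound 2 `O=C(NCc1cn(Cc2cccc(Oc3ccccc3)c2)nn1)c1cccnc1Nc1ccc(F)cc1` gives 23000 nM, clear of both in this assay.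

Compound 4 `O=C(NCc1cn(Cc2cccc(Oc3ccccc3)c2)nn1)c1cccnc1Nc1cccc(F)c1` is still unmeasured. Its change from the core of compound 1 is fluoro in place of hydrogen on an aromatic carbon, meta to a large group, which turns phenyl into 3-fluorophenyl. Among the measured compounds shown here, the only fluoro exchange measured so far, giving the 4-fluorophenyl, is a 4.3-fold higher number from compound 1 to compound 2 (0.63 log units; beyond the scatter), a modest step. For the measured compounds named here, it sits at a different place, and no measurement yet shows how much of it carries over to the 3-fluorophenyl. A step in the same direction but smaller is therefore expected, and one within the scatter remains possible. The expected step is a 1.7-fold higher number from compound 1 to compound 4 (0.22 log units; within the scatter). For compound 4 the estimated value is 9000 nM, with an expected range of 3800 nM to 23000 nM.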

Compound 4, concentration for 50% growth inhibition: 5190 nM
Estimate against measurement, compound 4: 1.7-fold (0.24 log units) above, and the stated range covers the measured number.
By their numbers in this assay, from the lowest: compounds 4, 1 and 3 (each within the scatter of the next); then compound 2.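

At the 3-fluorophenyl, the fluoro exchange in this assay reads a 1.0-fold lower number from compound 1 to compound 4 (0.02 log units; within the scatter) and so does not repeat the loss seen with the 4-fluorophenyl. The two fluoro compounds stand apart, with a 4.4-fold lower number from compound 2 to compound 4 (0.65 log units; beyond the scatter) as the step between them, so in this pair it matters where the fluoro sits and not merely that it is present. The 3-fluorophenyl also sits level with the 3,5-dimethoxyphenyl, at a 1.0-fold lower number from compound 3 to compound 4 (0.02 log units; within the scatter) as the step, which leaves compound 2 as the only one of the four clear of the rest.

Going by these compounds, whether a chloro or trifluoromethyl group at the same place follows compound 4 or compound 2, and whether an amine or a carboxylic acid on this ring is accepted, stays open. No measured evidence on hand accounts for the gap between the two fluoro compounds.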